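Series notes: from compound 2 toward compound 4

This account rests on a few compounds, and the source may have more. Where it says the series, first, only, none or still open, it means among the compounds named here.

Among the measured compounds shown here, compound 2 `COc1cc(Cl)cc(-c2nn(-c3cccc(NC(=O)Nc4ccc(Cl)c(C(F)(F)F)c4)c3)cc2-c2ccncc2)c1` gives 730 nM in a functional assay on U-251 cells (Homo sapiens) for inhibition, read by sulforhodamine B assay, with a stated time of 48 h (a higher number here means a weaker inhibitor, a lower number a stronger inhibitor), and stands second highest of the three numbers so far. For the measured compounds named here, compound 1 `O=C(Nc1cccc(-n2cc(-c3ccncc3)c(-c3cc(O)cc(Cl)c3)n2)c1)Nc1ccc(Cl)c(C(F)(F)F)c1` gives 1720 nM, and the step of a 2.4-fold lower number from compound 1 to compound 2 (0.37 log units; beyond the scatter) is the only single-site step measured. Going by the values given here, compound 3 `COc1cc(Cl)cc(-c2nn(-c3cccc(NC(=O)Nc4cc(C(F)(F)F)cc(C(F)(F)F)c4)c3)cc2-c2ccncc2)c1` gives 320 nM, a lower number than compound 2, but no single-site step links these two. Compound 4 `COc1cc(Cl)cc(-c2nn(-c3cccc(NC(=O)c4cccc(C(F)(F)F)c4)c3)cc2-c2ccncc2)c1` differs from compound 2 by 3-(trifluoromethyl)phenyl in place of (4-chloro-3-(trifluoromethyl)phenyl)amino on a carbonyl carbon. Among the compounds with values here, no measured step touches this part of the molecule; the one measured step concerns a methyl on an oxygen on an aromatic ring, so the direction here is open. For compound 4 the expected value is 1200 nM, with a range of 300 nM to 5000 nM. That estimate means an expected step of a 1.6-fold higher number from compound 2 to compound 4 (0.22 log units; within the scatter), possibly none beyond the scatter.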

Compound 4, half-maximal inhibitory concentration: 5560 nM
Compound 4: middle estimate off by 4.6-fold (0.67 log units), on the low side; the measured number lies above the stated range.
By their numbers in this assay, from the lowest: compound 3; then compound 2; then compound 1; then compound 4.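

Among the compounds shown here, the step of a 7.6-fold higher number from compound 2 to compound 4 (0.88 log units; beyond the scatter) in this assay is the first measured change on this carbonyl carbon, and it shows that the number responds to the group held there. The change removes the nitrogen with its hydrogen-bond donor and the chlorine together, so the step cannot be assigned to either one alone. Nothing measured here gives a cause for the step.

The compounds shown do not separate the nitrogen from the chlorine. Also open, from the compounds shown here alone, is how a saturated group, such as cyclohexylamino, would behave on this carbonyl carbon.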